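Ester Side-Chain Variation on a Shared Core

The source may report more compounds than this note shows. Statements on the series, on what has been measured and on what is new or still open speak of the compounds shown alone.

The measured compounds:
compound 1 `CCCCC(O)CC(=O)O[C@H](CC=C(C)C)C1=CC(=O)c2c(O)ccc(O)c2C1=O` gives 72200 nM in a functional assay on HeLa cells (Homo sapiens) for cytotoxicity, read by MTT assay; a lower number here means a stronger inhibitor, a higher number a weaker inhibitor.
compound 2 `CC(C)=CC[C@@H](OC(=O)c1ccoc1)C1=CC(=O)c2c(O)ccc(O)c2C1=O` reaches only the limit > 100000 nM in this assay.
compound 3 `CC(=O)OCCO[C@H](CC=C(C)C)C1=CC(=O)c2c(O)ccc(O)c2C1=O` gives 41500 nM in this assay.

Of the two numbers, the higher belongs to compound 1; the nearest value lies a 1.7-fold lower number from compound 1 to compound 3 (0.24 log units; within the scatter), within the scatter. Compound 4 `CC(C)=CC[C@@H](OC(=O)CC(C)(O)c1ccccc1)C1=CC(=O)c2c(O)ccc(O)c2C1=O` differs from compound 1 by 1-hydroxy-1-phenylethyl in place of 1-hydroxypentyl on a saturated chain carbon bound to a carbonyl carbon. The measured steps each exchange the whole ester group: an at least 1.3-fold higher number from compound 1 to compound 2 (0.14 log units; that floor lies within the scatter), where the limit of > 100000 nM in this assay, at which 1 of the 3 values shown sits, caps the reading, a 1.7-fold lower number from compound 1 to compound 3 (0.24 log units; within the scatter), and an at least 2.4-fold lower number from compound 2 to compound 3 (0.38 log units; beyond the scatter). None keeps the hydroxy ester and varies only its alkyl part as the step to compound 4 does, and only one passes the scatter. A step of a 1.2-fold lower number from compound 1 to compound 4 (0.08 log units; within the scatter) is therefore expected in this assay, not beyond the scatter. Compound 4 is estimated at 60000 nM, between 25000 nM and 130000 nM.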

Compound 4, half-maximal inhibitory concentration: 85700 nM
For compound 4 the middle estimate is 1.4-fold (0.15 log units) below the measured one; the range from low to high includes it.
By their numbers in this assay, from the lowest: compounds 3, 1 and 4 (each within the scatter of the next, the first and the last beyond it). At a limit, above all of these: compound 2.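

Among these compounds, replacing 1-hydroxypentyl with 1-hydroxy-1-phenylethyl is the only step here that keeps the hydroxy ester, and in this assay it gives a 1.2-fold higher number from compound 1 to compound 4 (0.07 log units; within the scatter), so at this place a six-membered aromatic ring enters without a step beyond the scatter. The step of an at least 1.1-fold lower number from compound 2 to compound 4 (0.06 log units; that floor lies within the scatter) can be read only as a floor. Compound 2 holds a limit, not a number: the limit of > 100000 nM in this assay, at which 1 of the 4 values shown sits.

The compounds shown leave open whether an amine or a carboxylic acid in place of the hydroxy group, or a longer chain, would move the number beyond the scatter.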